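The compounds below may be only part of what the source reports. "The series", "measured", "known", "first", "only" and "open" are said of these compounds alone.

Three measured compounds share one core and differ only in the group carried on the nitrogen on the aromatic ring. Compound 1 `COc1ccc(C(=O)Nc2cccc(/C=C/C(=O)c3nc4ccccc4[nH]3)c2)cc1` gives 6330 nM in a functional assay on 143B cells (Homo sapiens) for antiproliferative activity, read by MTT assay, with a stated time of 48 h; a lower number here means a stronger inhibitor, a higher number a weaker inhibitor. Compound 2 `O=C(/C=C/c1cccc(NS(=O)(=O)c2ccccc2Cl)c1)c1nc2ccccc2[nH]1` gives 4790 nM in this assay. Compound 3 `Cc1ccccc1S(=O)(=O)Nc1cccc(/C=C/C(=O)c2nc3ccccc3[nH]2)c1` gives 4060 nM in this assay. Compound 3 thus carries the lowest of the three numbers, yet a 1.6-fold lower number from compound 1 to compound 3 (0.19 log units; within the scatter) and a 1.2-fold lower number from compound 2 to compound 3 (0.07 log units; within the scatter) show that it is not set apart from the other two beyond the scatter, and the same holds for a 1.3-fold lower number from compound 1 to compound 2 (0.12 log units; within the scatter).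

Compound 4 `Cc1cc(C)cc(S(=O)(=O)Nc2cccc(/C=C/C(=O)c3nc4ccccc4[nH]3)c2)c1` differs from compound 3 by 3,5-dimethylphenyl in place of 2-methylphenyl on a sulfonyl sulfur. Among the measured compounds shown here, no measured step makes this exact change. The nearest step is the exchange of a substituent on the aromatic carbon of the ring attached to the sulfonyl sulfur, a 1.2-fold lower number from compound 2 to compound 3 (0.07 log units; within the scatter), which stayed within the scatter; the larger exchanges of the whole group on the nitrogen, a 1.3-fold lower number from compound 1 to compound 2 (0.12 log units; within the scatter) and a 1.6-fold lower number from compound 1 to compound 3 (0.19 log units; within the scatter), also stayed within the scatter. Compound 4 is therefore expected to show no step beyond the scatter, a 1.0-fold lower number from compound 3 to compound 4 (0.01 log units; within the scatter). Compound 4 is estimated at 4000 nM in this assay, with a range from 1500 nM to 11000 nM.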

Compound 4, half-maximal inhibitory concentration: 3330 nM
Compound 4: middle estimate off by 1.2-fold (0.08 log units), on the high side; the range from low to high includes it.
By their numbers in this assay, from the lowest: compounds 4, 3, 2 and 1 (each within the scatter of the next).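

In this assay, 3,5-dimethylphenyl on the sulfonyl sulfur gives a 1.2-fold lower number from compound 3 to compound 4 (0.09 log units; within the scatter) when it replaces 2-methylphenyl and a 1.4-fold lower number from compound 2 to compound 4 (0.16 log units; within the scatter) when it replaces 2-chlorophenyl. The earlier compounds shown here offered only the exchange of chloro for methyl on an aromatic carbon at this position, whereas three phenyl groups with different substitution, 2-chlorophenyl, 2-methylphenyl and 3,5-dimethylphenyl, now stand there with every step between them inside the scatter. Nothing measured here explains why these steps remain within the scatter.

Going by these compounds, whether an amine or a carboxylic acid on the ring attached to the sulfonyl sulfur, or a longer alkyl chain in place of that ring, would give a step beyond the scatter remains open. All four compounds keep the shared core unchanged and each lies within the scatter of the next, so the compounds shown do not tell which part of the structure, if any, governs the number in this assay.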